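From 2-fluorophenyl to 3-fluorophenyl on a shared core

The source may hold more compounds than are shown below. What is called first, only, known or untested is meant among the compounds shown, and "the series" means these compounds.

Measured so far in a functional assay on Hep 3B2 cells (Homo sapiens) for cytotoxicity, read by MTT assay, with a stated time of 48 h; a higher number here means a weaker inhibitor, a lower number a stronger inhibitor:
- compound 1 `COc1ccc2[nH]c(-c3cccc(F)c3)cc(=O)c2c1O` gives 70 nM
- compound 2 `O=c1cc(-c2ccc(F)cc2)[nH]c2ccc(O)c(O)c12` gives 100000 nM
- compound 3 `COc1cc2c(=O)cc(-c3ccccc3F)[nH]c2cc1O` gives 5300 nM

Among these three compounds, compound 3 holds the middle place. Its number is the second highest, lying below that of compound 2 and above that of compound 1, and both gaps are beyond the scatter.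

The next compound to be tested is compound 4 `COc1cc2c(=O)cc(-c3cccc(F)c3)[nH]c2cc1O`, which has the same core as compound 3. For the measured compounds named here, the only change is 3-fluorophenyl in place of 2-fluorophenyl on an aromatic carbon, next to the ring nitrogen (3-fluorophenyl in place of 2-fluorophenyl on an aromatic carbon). Going by the values given here, no measured pair isolates this kind of change, so the data offer no direct precedent. The one indirect clue is that compound 1, which also carries 3-fluorophenyl, gives 70 nM on a different core. That value favours a lower number for compound 4, but it is only a loose guide.

A moderate move towards stronger inhibition, probably beyond the scatter, is therefore expected, with the estimated change a 3.5-fold lower number from compound 3 to compound 4 (0.55 log units; beyond the scatter) in this assay. Compound 4 is estimated at 1500 nM, with an expected range from 200 nM to 10000 nM.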

Compound 4, half-maximal inhibitory concentration: 5300 nM
Compound 4: middle estimate off by 3.5-fold (0.55 log units), on the low side, and the stated range covers the measured number.
By their numbers in this assay, from the lowest: compound 1; then compounds 3 and 4 (each within the scatter of the next); then compound 2.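

Exchanging 2-fluorophenyl for 3-fluorophenyl on this aromatic carbon of the shared core gives no change at the digits printed from compound 3 to compound 4 (within the scatter) in this assay. For the compounds shown here, this is the first pair to isolate this change, and it shows that on this core, at this position, the two fluorophenyl groups cannot be told apart in this read-out. The step therefore offers no sign that this exchange alone moves the number here, and no measurement at hand bears on why the two groups read alike.

The compounds shown leave open whether any group other than a fluorophenyl at this carbon, such as an unsubstituted phenyl or a phenyl carrying an amine or a carboxylic acid, would move the number on this core. Going by these compounds, it also remains open whether the same exchange would prove equally silent on the core of compound 1 or on the core of compound 2, where the surrounding groups on the core differ.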